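The source may hold more compounds than are shown below. What is called first, only, known or untested is meant among the compounds shown, and "the series" means these compounds.

Measured so far:
compound 1 `O=S(=O)(c1cc(Cl)cc(Cl)c1)c1cnc2cc(F)ccc2c1-c1ccc(F)cc1` — 0.18 mL/min
compound 2 `O=S(=O)(c1cc(Cl)cc(Cl)c1)c1cnc2cc(F)ccc2c1-c1cccc(F)c1` — 0.41 mL/min
compound 3 `COc1ccc(S(=O)(=O)c2cnc3cc(F)ccc3c2-c2cccc(F)c2)cc1` — 2.94 mL/min

Of the compounds shown here, three have been measured in an ADME assay on microsomes from liver (Homo sapiens) for metabolic stability, tested at 2.5 uM; a lower number here means slower removal, a higher number faster removal of the compound. Compound 1 `O=S(=O)(c1cc(Cl)cc(Cl)c1)c1cnc2cc(F)ccc2c1-c1ccc(F)cc1` gives 0.18 mL/min in this assay, compound 2 `O=S(=O)(c1cc(Cl)cc(Cl)c1)c1cnc2cc(F)ccc2c1-c1cccc(F)c1` gives 0.41 mL/min, and compound 3 `COc1ccc(S(=O)(=O)c2cnc3cc(F)ccc3c2-c2cccc(F)c2)cc1` gives 2.94 mL/min, the highest of the three numbers.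

Compound 1 and compound 2 share a core and differ only in one place: 4-fluorophenyl in place of 3-fluorophenyl on an aromatic carbon The step is a 2.3-fold lower number from compound 2 to compound 1 (0.36 log units; beyond the scatter). Compound 2 and compound 3 differ at the sulfonyl sulfur: 4-methoxyphenyl in place of 3,5-dichlorophenyl on a sulfonyl sulfur That step is a 7.2-fold higher number from compound 2 to compound 3 (0.86 log units; beyond the scatter).

Compound 4 `COc1ccc(S(=O)(=O)c2cnc3cc(F)ccc3c2-c2ccc(F)cc2)cc1` has not yet been measured. It stands to compound 3 as compound 1 stands to compound 2: 4-fluorophenyl in place of 3-fluorophenyl on an aromatic carbon The place described for this change is the same, word for word, as for the change from compound 2 to compound 1, so it is the same change made on a different core. For the measured compounds named here, the change from compound 2 to compound 1 gave a 2.3-fold lower number from compound 2 to compound 1 (0.36 log units; beyond the scatter), and it is the only example of this change with a measured outcome. Going by the values given here, compound 4 is therefore expected to show a step of about a 2.3-fold lower number from compound 3 to compound 4 (0.35 log units; beyond the scatter), a step of similar size to the earlier one, because the starting value of compound 3 is 2.94 mL/min and the only measured instance of this change is a 2.3-fold lower number from compound 2 to compound 1 (0.36 log units; beyond the scatter). Among the compounds with values here, with only a single precedent, the range around this expectation is kept wide. Compound 4 is expected to give about 1.3 mL/min, estimated between 0.6 mL/min and 2.9 mL/min.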

Compound 4, intrinsic clearance in a liver preparation (reported as CLH), per the amount of preparation that the assay uses: 1.71 mL/min
For compound 4 the middle estimate is 1.3-fold (0.12 log units) below the measured one; the range from low to high includes it.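

In this assay, 4-fluorophenyl in place of 3-fluorophenyl gives a 1.7-fold lower number from compound 3 to compound 4 (0.24 log units; within the scatter), and the size of this step agrees with that of the same change on the core carrying 3,5-dichlorophenyl: the same change on two cores in this assay, a 2.3-fold lower number (0.36 log units; beyond the scatter) from compound 2 to compound 1 and a 1.7-fold lower number (0.24 log units; within the scatter) from compound 3 to compound 4, 1.3-fold (0.12 log units) apart, within the scatter of two such steps. The change on the sulfonyl sulfur, 4-methoxyphenyl in place of 3,5-dichlorophenyl, gives a 9.5-fold higher number from compound 1 to compound 4 (0.98 log units; beyond the scatter), and it also carries over from one core to the other without a difference beyond the scatter: the same change on two cores in this assay, a 7.2-fold higher number (0.86 log units; beyond the scatter) from compound 2 to compound 3 and a 9.5-fold higher number (0.98 log units; beyond the scatter) from compound 1 to compound 4, 1.3-fold (0.12 log units) apart, within the scatter of two such steps. For the compounds shown here, the four compounds form a single square, however, so each change has been followed on only two cores, and this agreement shows neither that the steps would hold on a core differing elsewhere nor what sets their size.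

The compounds shown leave open how this assay would respond to a sulfonyl substituent other than these two aryl groups, such as an amine or a simple alkyl chain. They also leave open what a carboxylic acid or an amine on the fluorophenyl group would do, and whether either step would keep its size with such a group present.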